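The compounds below may be only part of what the source reports. "The series", "measured", "known", "first", "only" and "open" are said of these compounds alone.

Of the compounds shown here, three sharing one core have been tested in a functional assay on the whole organism (strain albino) for inhibition, with Rattus norvegicus as the target, read by paw edema, with stated times of 1 h and 2 h, at a dose of 20 mmol/kg by the intraperitoneal route; a lower number here means less inhibition, a higher number more inhibition at the dose given (going by the name of the read-out). Compound 1 `N#CC1=C(NCC(=O)N2CCOCC2)N(c2ccccc2)C(=O)N2CCCCC(N3CCCC3)C12` gives 69.8%. Compound 2 `N#CC1=C(/N=C/Nc2ccc([N+](=O)[O-])cc2)N(c2ccccc2)C(=O)N2CCCCC(N3CCCC3)C12` gives 41.5%. Compound 3 `N#CC1=C(NCC(=O)N2CCCC2)N(c2ccccc2)C(=O)N2CCCCC(N3CCCC3)C12` gives 49.8%, which places it second highest of the three; its nearest neighbour is compound 2, and the gap between them is within the scatter (a number 8.3 percentage points higher from compound 2 to compound 3 (within the scatter)), while its furthest is compound 1, from which it differs beyond the scatter (a number 20 percentage points lower from compound 1 to compound 3 (beyond the scatter)).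

The next compound, compound 4 `COc1ccc(N/C=N/C2=C(C#N)C3C(N4CCCC4)CCCCN3C(=O)N2c2ccccc2)cc1`, changes compound 3 in one place: a group of 11 heavy atoms (8 carbon, 2 nitrogen, 1 oxygen; one six-membered aromatic ring of carbon only) in place of a group of 9 heavy atoms (6 carbon, 2 nitrogen, 1 oxygen; one five-membered non-aromatic ring with 1 hetero atom), on a double-bonded ring carbon

Among the compounds with values here, two measured steps bear on this. Within the data shown here, the closest is the reverse of the one from compound 2 to compound 3, in which a pyrrolidine amide side chain and an aryl formamidine side chain gave numbers within the scatter of each other (a number 8.3 percentage points higher from compound 2 to compound 3 (within the scatter)). The other is the step from a morpholine amide to the same aryl formamidine, which was beyond the scatter (a number 28.3 percentage points lower from compound 1 to compound 2 (beyond the scatter)). Compound 4 carries a methoxyphenyl rather than a nitrophenyl on its formamidine, a change for which no comparison exists here. On this basis a step of a number 7.8 percentage points lower from compound 3 to compound 4 (within the scatter) is expected, a small decrease that may well lie within the scatter, so compound 4 is estimated at 42%, within a range from 25% to 60%.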

Compound 4, a percentage reported as inhibition, in the whole organism at one dose (the size of the read-out at that dose, not a potency): 37.2%
Estimate against measurement, compound 4: 4.8 percentage points above, within the range that was stated.
By their numbers in this assay, from the lowest: compounds 4, 2 and 3 (each within the scatter of the next, the first and the last beyond it); then compound 1.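

Replacing nitro with methoxy on the aromatic ring of the formamidine, the first change made on that ring among these compounds, gives a step within the scatter (a number 4.3 percentage points lower from compound 2 to compound 4 (within the scatter)), so in this assay this pair does not separate the two groups. The new compound does separate the formamidine side chain from the pyrrolidine amide, with a number 12.6 percentage points lower from compound 3 to compound 4 (beyond the scatter), although compound 2 stays within the scatter of compound 3, so the two formamidines do not fall clearly below the pyrrolidine amide as a pair. The morpholine amide now stands clear of a second formamidine, with a number 32.6 percentage points lower from compound 1 to compound 4 (beyond the scatter), and no supporting data at hand explain any of these steps.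

The compounds shown leave open how a formamidine with an unsubstituted phenyl, or with a chlorine or a carboxylic acid on the ring, would read at this dose. They also leave open whether the higher number of the morpholine amide carries over to a piperidine amide, or to a longer carbon chain between the amino nitrogen and the carbonyl.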